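Thiourea quinazoline series: trifluoromethyl to methyl step

The compounds below may be only part of what the source reports. "The series", "measured", "known", "first", "only" and "open" are said of these compounds alone.

Measured so far, all in a functional assay on NCI-H1975 cells (Homo sapiens) for antiproliferative activity, read by MTT assay, with a stated time of 72 h; on this read-out higher numbers stand for weaker inhibition and lower numbers for stronger inhibition:
compound 1, `NS(=O)(=O)c1ccc(NC(=S)Nc2ccc3ncnc(Nc4ccc(F)c(Cl)c4)c3c2)cc1`, gives 15800 nM.
compound 2, `NS(=O)(=O)c1ccc(NC(=S)Nc2ccc3ncnc(Nc4ccc(F)c(Br)c4)c3c2)cc1`, gives 9980 nM.
compound 3, `NS(=O)(=O)c1ccc(NC(=S)Nc2ccc3ncnc(Nc4ccc(C(F)(F)F)cc4)c3c2)cc1`, gives 17100 nM.

Compound 3 carries the highest of the three numbers, yet both of its neighbours sit within the scatter: a 1.1-fold higher number from compound 1 to compound 3 (0.03 log units; within the scatter) and a 1.7-fold higher number from compound 2 to compound 3 (0.23 log units; within the scatter). Within the data shown here, the one step inside the set that changes only a single substituent, a 1.6-fold lower number from compound 1 to compound 2 (0.20 log units; within the scatter), is also within the scatter. On these numbers the three compounds are not separated.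

Compound 4, `Cc1ccc(Nc2ncnc3ccc(NC(=S)Nc4ccc(S(N)(=O)=O)cc4)cc23)cc1`, is still to be measured. It differs from compound 3 by methyl in place of trifluoromethyl on an aromatic carbon. Among the measured compounds shown here, no measured step isolates this exact exchange; the steps that bear on it are those in which the whole 4-(trifluoromethyl)phenyl group was swapped against a 3-chloro-4-fluorophenyl or 3-bromo-4-fluorophenyl group, and both were within the scatter. Nothing in the set points to a change beyond the scatter in this assay for a smaller substituent at the same place.

Compound 4 is therefore expected to land close to compound 3, an estimated step of a 1.1-fold lower number from compound 3 to compound 4 (0.03 log units; within the scatter). The estimate for compound 4 is 16000 nM, with a range from 6000 nM to 45000 nM.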

Compound 4, half-maximal inhibitory concentration: 39400 nM
Compound 4: middle estimate off by 2.5-fold (0.39 log units), on the low side, and the stated range covers the measured number.
By their numbers in this assay, from the lowest: compounds 2, 1 and 3 (each within the scatter of the next); then compound 4.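

Working notes: in this assay, the exchange of trifluoromethyl for methyl on this aromatic carbon, para to a large group, gives the first single-place change in the set to leave the scatter, with a 2.3-fold higher number from compound 3 to compound 4 (0.36 log units; beyond the scatter) as its step. The 4-methylphenyl group also separates from both halogenated aryl groups, with a 3.9-fold higher number from compound 2 to compound 4 (0.60 log units; beyond the scatter) and a 2.5-fold higher number from compound 1 to compound 4 (0.40 log units; beyond the scatter), whereas the 4-(trifluoromethyl)phenyl group could not be told apart from them; compound 4 is thus the weakest of the four in this read-out, and this place on the aryl ring responds to the substituent, though all of these steps are modest. No measurement at hand accounts for the loss on going to methyl, so the step stands as an observation without an explanation.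

As far as these compounds go, it remains open how this place behaves with other groups, such as an amine, a methoxy group or a carboxylic acid, and so whether trifluoromethyl or methyl is the unusual member of the pair. From the compounds shown here alone, it is equally open whether the same exchange would give a step of similar size in an aryl group that also carries a halogen, such as 3-chloro-4-methylphenyl in place of 3-chloro-4-(trifluoromethyl)phenyl.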